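The compounds below may be only part of what the source reports. "The series", "measured", "known", "first", "only" and "open" are said of these compounds alone.

The measured compounds are:
compound 1, `CCCCCCCCCOc1ccccc1C(SCCC(=O)O)SCCC(=O)O`, which in an assay on membranes from lung (Cavia porcellus) for binding affinity to cysteinyl leukotriene receptor (Homo sapiens) (on this read-out higher numbers stand for weaker inhibition and lower numbers for stronger inhibition), gives 4090 nM;
compound 2, `O=C(O)CCSC(SCCC(=O)O)c1ccccc1OCCCCCCc1ccccc1`, which gives 11500 nM;
compound 3, `O=C(O)CCSC(SCCC(=O)O)c1ccccc1OCCCC1CCCCC1`, which gives 1010 nM.

Compound 3 stands lowest of the three numbers. Its nearest neighbour is compound 1, with a 4.0-fold lower number from compound 1 to compound 3 (0.61 log units; beyond the scatter), and its furthest is compound 2, with an 11-fold lower number from compound 2 to compound 3 (1.06 log units; beyond the scatter); between the other two lies a 2.8-fold higher number from compound 1 to compound 2 (0.45 log units; beyond the scatter).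

Compound 4, `CCOCCOCCOCCOc1ccccc1C(SCCC(=O)O)SCCC(=O)O`, continues the series at the same place: 2-(2-ethoxyethoxy)ethoxy in place of cyclohexylmethyl on a saturated chain carbon, two bonds along the chain from an oxygen on an aromatic ring. All three measured steps vary the chain on the aromatic oxygen, and they show that this chain matters beyond the scatter in both directions, with the cyclohexyl-bearing chain of compound 3 giving the lowest number. Among the measured compounds shown here, none of them brings oxygen into that chain, so there is no direct precedent for compound 4, and the expectation rests on the spread of the three numbers. It is expected that the change gives back much of what compound 3 gained, so that a 5.9-fold higher number from compound 3 to compound 4 (0.77 log units; beyond the scatter) is expected, a rise toward the numbers of compound 1 and compound 2. Compound 4 is therefore estimated at 6000 nM, within a range from 1500 nM to 25000 nM.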

Compound 4, inhibition constant: > 20000 nM
Compound 4: a limit, no number; the forecaster's own chance of this, stated with the estimate: 10%; middle value at least 3.3-fold (0.52 log units) from the limit.
By their numbers in this assay, from the lowest: compound 3; then compound 1; then compound 2. At a limit, above all of these: compound 4.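

In this assay compound 4 gives > 20000 nM, a limit of the assay and not a number, so its reading is bounded on one side only: the limit of > 20000 nM in this assay, at which 1 of the 4 values shown sits.

Until now this position had carried only chains of carbon, and the first chain with oxygen in it, 2-(2-ethoxyethoxy)ethoxy, shows an at least 19-fold higher number from compound 3 to compound 4 (1.29 log units; beyond the scatter) and an at least 4.8-fold higher number from compound 1 to compound 4 (0.68 log units; beyond the scatter), so it loses clearly to both the cyclohexylmethyl-bearing chain and the plain heptyl-bearing chain. Against the 4-phenylbutyl-bearing chain the limit gives only an at least 1.7-fold higher number from compound 2 to compound 4 (0.24 log units; that floor lies within the scatter), so these data do not tell whether the new chain is any worse than the poorest of the carbon chains.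

The comparison with compound 3 changes the ring and the oxygen content at once, and the step from compound 1 also changes the size of the group, so the share of the oxygen atoms alone stays unresolved. Also open, from the compounds shown here alone, are how far past its limit compound 4 really lies and whether a chain with a single ether oxygen, a terminal hydroxyl or an amine at this place would behave in the same way.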